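The source may report more compounds than this note shows. Statements on the series, on what has been measured and on what is new or still open speak of the compounds shown alone.

Compound 1 `COc1ccc(-n2nc(C(C)=O)s/c2=N\c2nc(-c3c(C)n(C)n(-c4ccccc4)c3=O)cs2)cc1`: 64500 nM
Compound 2 `CC(=O)c1nn(-c2ccc([N+](=O)[O-])cc2)/c(=N/c2nc(-c3c(C)n(C)n(-c4ccccc4)c3=O)cs2)s1`: > 100000 nM

Going by the values given here, in a functional assay on MCF7 cells (Homo sapiens) for cytotoxicity, read by sulforhodamine B assay, with a stated time of 72 h (a higher number here means a weaker inhibitor, a lower number a stronger inhibitor), compound 1 gives 64500 nM, the only number among the two values shown. Compound 2 is reported only as a limit of the assay, > 100000 nM. Among the compounds with values here, the single measured step, an at least 1.5-fold higher number from compound 1 to compound 2 (0.19 log units; that floor lies within the scatter), runs into that limit (the limit of > 100000 nM in this assay, at which 1 of the 2 values shown sits). Compound 3 `CCOC(=O)c1nn(-c2ccc(OC)cc2)/c(=N/c2nc(-c3c(C)n(C)n(-c4ccccc4)c3=O)cs2)s1` differs from compound 1 by ethoxy in place of methyl on a carbonyl carbon. Within the data shown here, no measured step touches the carbonyl carbon, so the step from compound 1 to compound 2 does not bear on this change. For compound 3 the expected step is a 1.2-fold higher number from compound 1 to compound 3 (0.09 log units; within the scatter), nothing beyond the scatter. Compound 3 is therefore estimated at 80000 nM, between 30000 nM and 200000 nM in this assay.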

Compound 3, half-maximal inhibitory concentration: 15900 nM
The estimate for compound 3 lay 5.0-fold (0.70 log units) above the measured number; measured number outside the range, below it.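

Going by these compounds alone, the carbonyl carbon is a position to which the series responds in this assay: ethoxy in place of methyl gives a 4.1-fold lower number from compound 1 to compound 3 (0.61 log units; beyond the scatter) and is the first step here sized beyond the scatter. The earlier pair changed only a group on an aromatic carbon and ended at a limit of the assay. No measured property accounts for this step.

On these data alone, whether the change depends on the ethoxy oxygen or the added carbons stays open; a propyl ketone, a carboxylic acid or an amide on this carbon would help separate them. Also open, as far as these compounds go, is how nitro in place of methoxy behaves alongside ethoxycarbonyl.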